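Ring-hydroxylation step in the dihydroflavonol series

This account rests on a few compounds, and the source may have more. Where it says the series, first, only, none or still open, it means among the compounds named here.

Measured compounds in a functional assay on RAW264.7 cells (Rattus norvegicus) for inhibition, with RAW264.7 (Mus musculus) as the target, read by Griess assay, with stated times of 2 h and 16 h; a lower number here means a stronger inhibitor, a higher number a weaker inhibitor:
- compound 1, `Cc1ccc2c(c1)C(=O)C(O)C(c1cccc(O)c1O)O2`: 45300 nM
- compound 2, `O=C1c2ccccc2O[C@@H](c2cccc(O)c2O)[C@@H]1O`: > 100000 nM (a limit of the assay)
- compound 3, `O=C1c2ccc(O)cc2O[C@@H](c2cccc(O)c2O)[C@@H]1O`: > 100000 nM (a limit of the assay)

In this assay, among the compounds with values here, compound 1 gives 45300 nM, the only numerical value in the set. For compound 2 the read-out is a limit of the assay, > 100000 nM. For compound 3 the read-out is likewise a limit, > 100000 nM. Compound 2 therefore stands at the weak end of what the assay can report, with no number to anchor it.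

Within the data shown here, the single measured one-point step is a step that the two limits leave unreadable from compound 2 to compound 3. Its size cannot be read because both ends sit at the limit of > 100000 nM in this assay, at which 2 of the 3 values shown sit.

Compound 4, `O=C1c2cc(O)ccc2O[C@@H](c2cccc(O)c2O)[C@@H]1O`, differs from compound 2 by hydroxy in place of hydrogen on an aromatic carbon. The hydroxy enters meta to a fused ring and para to a fused ring. The only measured change that resembles it is the step from compound 2 to compound 3, and that step is unreadable, so no direction or size can be taken from the shown numbers. The expectation for compound 4 in this assay is therefore a step that the limit leaves unreadable from compound 2 to compound 4 that is not expected to exceed the scatter. The estimate for compound 4 is 120000 nM, within 50000 nM to 300000 nM, most likely reported again as a limit.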

Compound 4, half-maximal inhibitory concentration: > 100000 nM
Compound 4: a limit, no number; the forecaster's own chance of this, stated with the estimate: 70%; the middle value is on the limit's open side.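

In this assay compound 4 gives > 100000 nM, a limit of the assay. No step can be read between compound 2 and compound 4, because both read-outs are limits: the limit of > 100000 nM in this assay, at which 3 of the 4 values shown sit.

The compounds shown leave open whether hydroxy in place of hydrogen on an aromatic carbon changes the inhibition given by compound 2 at all, and in which direction.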